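Dichloro-to-monochloro step on a benzylated purine core

The compounds below may be only part of what the source reports. "The series", "measured", "known", "first", "only" and "open" are said of these compounds alone.

Measured so far:
compound 1 `ClCc1ccc(Cn2cnc3c(Cl)ncnc32)cc1` gives 4160 nM
compound 2 `ClCc1ccccc1Cn1cnc2c(Cl)nc(Cl)nc21` gives 3270 nM

Two compounds have been run in a functional assay on NCI-H322M cells (Homo sapiens) for cytotoxicity, read by sulforhodamine B assay, with a stated time of 48 h; a higher number here means a weaker inhibitor of growth, a lower number a stronger inhibitor of growth. Compound 2 holds the lowest of the two numbers, with compound 1 the nearest, and the two values lie within the scatter of each other, so no order between them can be read. Among the compounds with values here, no single-change pair among the measured compounds exists, so no measured step is available.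

Compound 3 `ClCc1ccccc1Cn1cnc2c(Cl)ncnc21` is not yet measured. Relative to compound 2 the change is hydrogen in place of chloro on an aromatic carbon. Compound 3 carries the same core as compound 1, with a different benzyl group.

Within the data shown here, with no measured step to lean on, the expectation rests on the two numbers at hand, which sit close together; the step from compound 2 to compound 3 is expected to be small, a 1.2-fold higher number from compound 2 to compound 3 (0.09 log units; within the scatter), and in either direction within the scatter. Compound 3 is therefore estimated at 4000 nM, with a range from 1500 nM to 11000 nM in this assay.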

Compound 3, concentration for total growth inhibition: 13800 nM
Beside the measured number, compound 3's estimate is 3.5-fold (0.54 log units) below it, and the stated range ends below it.
By their numbers in this assay, from the lowest: compounds 2 and 1 (each within the scatter of the next); then compound 3.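

In this assay, within the data shown here, the pair of compound 2 and compound 3 gives the first measured single change: hydrogen in place of chloro on an aromatic carbon, between two ring nitrogen atoms, is a step of a 4.2-fold higher number from compound 2 to compound 3 (0.63 log units; beyond the scatter). The two earlier compounds could not show this, as they differ in more than one place and their values lie within the scatter of each other. In this pair, then, the chloro group at this position goes with the lower number, a modest step but one that can be read, and nothing available on these compounds accounts for the size or direction of that step.

A single pair cannot show whether the step holds when the chloromethyl group sits as it does in compound 1, so the finding stays tied to the benzyl group shared by compound 2 and compound 3. Also open, on these data alone, is what an amine, a methoxy group or a fluoro group would give in place of chloro at this position, which would show whether the step is particular to chloro or extends to other groups.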